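Aryl exchange at the amide end of a limit-bound series

The source may report more compounds than this note shows. Statements on the series, on what has been measured and on what is new or still open speak of the compounds shown alone.

Compound 1, `COc1ccc(CNC(=O)/C=C/c2coc3cc(OC)ccc3c2=O)cc1`, is measured only as a limit in a functional assay on HeLa cells (Homo sapiens) for inhibition, read by MTT assay, with a stated time of 48 h; on this read-out higher numbers stand for weaker inhibition and lower numbers for stronger inhibition: compound 1 gives > 100000 nM, the limit of the assay and not a number. Compound 2, `COc1ccc(CNC(=O)/C=C/c2coc3cc(O)ccc3c2=O)cc1`, also returns a limit, > 100000 nM. Compound 3, `COc1ccc(NC(=O)/C=C/c2coc3cc(O)ccc3c2=O)cc1`, likewise sits at a limit, > 100000 nM. Within the data shown here, the one step that can be read as a single change, a step that the two limits leave unreadable from compound 1 to compound 2, is therefore of unreadable size, and the pairs without a computed step show nothing beyond two limits each. Evidence on the whole set is the limit of > 100000 nM in this assay, at which 3 of the 3 values shown sit.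

Compound 4, `COc1ccc2c(=O)c(/C=C/C(=O)NCc3ccc(F)cc3F)coc2c1`, differs from compound 1 by 2,4-difluorophenyl in place of 4-methoxyphenyl on a saturated chain carbon bound to an amide-type nitrogen. Among the measured compounds shown here, no measured step bears on this exchange, and the only measured step, a step that the two limits leave unreadable from compound 1 to compound 2, is itself unreadable. An expectation for this assay can rest only on the fact that every measured value sits at the limit.

Compound 4 is therefore expected to sit near the limit as well, with an estimated value of 150000 nM, between 40000 nM and 600000 nM. The step this estimate implies, a step that the limit leaves unreadable from compound 1 to compound 4, is expected to be no more than scatter.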

Compound 4, half-maximal inhibitory concentration: > 100000 nM
Compound 4 ended at the assay's limit; the forecaster's own chance of this, stated with the estimate: 75%; the middle value does not contradict the limit.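

In this assay compound 4 gives > 100000 nM, a limit and not a number. Among these compounds, compound 1 also stands at a limit, so no step between compound 1 and compound 4 can be read. The compounds shown leave open whether any exchange at the amide end gives a readable value in this assay.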